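This account rests on a few compounds, and the source may have more. Where it says the series, first, only, none or still open, it means among the compounds named here.

Working notes on the series. In a functional assay on MCF-10A cells (Homo sapiens) for antiproliferative activity, with a stated time of 48 h (on this read-out higher numbers stand for an effect only at larger amounts of compound and lower numbers for an effect already at smaller amounts), compound 2 (`Cc1cc(NCc2ccc(F)cc2)c2ccccc2n1`) gives 15400 nM. Compound 1 (`COc1ccc2nc(C)cc(NCc3cccc(C#N)c3)c2c1`) gives 13400 nM and compound 3 (`COc1ccc2c(NCc3ccc(F)cc3)cc(C)nc2c1`) gives 10200 nM. Compound 2 lies within the scatter of both, so it holds no distinct place among the three numbers.

The next compound is compound 4 (`CCCOc1ccc2nc(C)cc(NCc3ccc(F)cc3)c2c1`), which is compound 2 with propoxy in place of hydrogen on an aromatic carbon.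

For the measured compounds named here, one measured step bears on this change, the replacement of hydrogen by methoxy on an aromatic carbon, which gives a 1.5-fold lower number from compound 2 to compound 3 (0.18 log units; within the scatter). That step does not rise above the scatter. Compound 1 also carries a methoxy, but it has a nitrile where compound 2 has fluorine, so it offers no clean comparison. Going by the values given here, no measured compound carries propoxy, so the extension from methoxy to propoxy remains untested, and the expected range is kept wide.

In this assay no change beyond the scatter is expected, with at most a slight drift towards a lower number. The estimated change is a 1.5-fold lower number from compound 2 to compound 4 (0.19 log units; within the scatter). For compound 4 the expected value is 10000 nM, with an estimated range of 4500 nM to 20000 nM.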

Compound 4, half-maximal effective concentration: 9800 nM
For compound 4 the middle estimate is 1.0-fold (0.01 log units) above the measured one; measured number inside the range.
By their numbers in this assay, from the lowest: compounds 4, 3, 1 and 2 (each within the scatter of the next).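

In this assay propoxy on this aromatic carbon, meta to a fused ring and para to a fused ring, gives a 1.6-fold lower number from compound 2 to compound 4 (0.20 log units; within the scatter) and so adds 4 heavy atoms here with no change that rises above the scatter. Only compound 4 carries propoxy among the compounds shown, and the four numbers now form a run in which each lies within the scatter of the next, so neither this group nor the methoxy of compound 3 sets a compound apart. Compound 3 and compound 4 differ in more than one place, so their values do not amount to a reading of methoxy against propoxy. No supporting measurement bears on this result.

As far as these compounds go, whether a longer chain such as butoxy, or a propoxy chain ending in an amine or a carboxylic acid, would move the number beyond the scatter remains open. Also open, from the compounds shown here alone, is whether any substituent on this carbon can separate a compound from the others here, since every step read so far stays within the scatter.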